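The source may hold more compounds than are shown below. What is called first, only, known or untested is meant among the compounds shown, and "the series" means these compounds.

Of the compounds shown here, three sharing one core have been measured. Compound 1 `NC(=O)c1c(NC(=O)c2ccccc2Cl)sc2c1CCN(Cc1ccccc1)C2` gives 12000 nM in a functional assay on HL-60 cells (Homo sapiens) for antiproliferative activity, with a stated time of 24 h; on this read-out higher numbers stand for weaker inhibition and lower numbers for stronger inhibition. Compound 2 `NC(=O)c1c(NC(=O)c2ccccc2Cl)sc2c1CCN(Cc1cc(Cl)cc(Cl)c1)C2` gives 15800 nM in this assay, and compound 3 `NC(=O)c1c(NC(=O)c2ccccc2Cl)sc2c1CCN(C(=S)Nc1ccccc1Br)C2` gives 9090 nM in this assay. Compound 3 has the lowest of the three numbers, though each step toward it lies within the scatter: a 1.3-fold lower number from compound 1 to compound 3 (0.12 log units; within the scatter) and a 1.7-fold lower number from compound 2 to compound 3 (0.24 log units; within the scatter). Compound 4 `NC(=O)c1c(NC(=O)c2ccccc2Cl)sc2c1CCN(C(=S)Nc1c(Cl)cccc1Cl)C2` differs from compound 3 by 2,6-dichlorophenyl in place of 2-bromophenyl on an amide-type nitrogen. The closest measured precedent for adding halogen to an aromatic ring is a 1.3-fold higher number from compound 1 to compound 2 (0.12 log units; within the scatter), a change made elsewhere in the core; the other two steps also stayed within the scatter. Going by the values given here, nothing measured so far has moved this assay beyond the scatter, so no step beyond it is expected here. In this assay the estimated step is a 1.0-fold lower number from compound 3 to compound 4 (0.00 log units; within the scatter). Compound 4 is therefore expected to give about 9000 nM in this assay, with a range from 4000 nM to 20000 nM.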

Compound 4, half-maximal inhibitory concentration: 3950 nM
For compound 4 the middle estimate is 2.3-fold (0.36 log units) above the measured one; the measured number lies below the stated range.
By their numbers in this assay, from the lowest: compound 4; then compounds 3, 1 and 2 (each within the scatter of the next).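

In this assay, going by these compounds alone, the group on the amide-type nitrogen proves able to move the number: 2,6-dichlorophenyl in place of 2-bromophenyl gives a 2.3-fold lower number from compound 3 to compound 4 (0.36 log units; beyond the scatter) and is the first single change in this set to pass beyond the scatter. With 2,6-dichlorophenyl on that nitrogen, the group on the ring amine nitrogen also separates from the earlier arylmethyl groups, giving a 4.0-fold lower number from compound 2 to compound 4 (0.60 log units; beyond the scatter) and a 3.0-fold lower number from compound 1 to compound 4 (0.48 log units; beyond the scatter), whereas compound 3 stayed within the scatter of both compound 1 and compound 2. No evidence is available that accounts for this shift.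

The compounds shown leave open whether the shift follows the chlorine atoms or their arrangement in 2,6-dichlorophenyl, which 2-chlorophenyl and 2,6-dibromophenyl on the same nitrogen would help separate. Also open, from the compounds shown here alone, is whether a carbonyl could stand in place of the thiocarbonyl carbon.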